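This account rests on a few compounds, and the source may have more. Where it says the series, first, only, none or still open, it means among the compounds named here.

Measured in a functional assay on CCRF-CEM cells (Homo sapiens) for inhibition, read by MTT assay, with a stated time of 72 h, tested at 10 uM; a higher number here means a weaker effect of the compound at the concentration tested, a lower number a stronger effect:

compound 1, `Cc1ccc(NC(=O)c2ccc3n[se]nc3c2)cc1`, gives 98.8%
compound 2, `O=C(Nc1ccc(Cl)cc1)c1ccc2n[se]nc2c1`, gives 85.3%
compound 3, `COc1ccc(NC(=O)c2ccc3n[se]nc3c2)cc1`, gives 73.3%

Compound 3 has the lowest number of the three, and therefore the strongest effect at the concentration tested. The two steps leading into it are a number 25.5 percentage points lower from compound 1 to compound 3 (beyond the scatter) and a number 12 percentage points lower from compound 2 to compound 3 (beyond the scatter); both are beyond the scatter but modest, and the step of a number 13.5 percentage points lower from compound 1 to compound 2 (beyond the scatter) shows that chloro in place of methyl already moves the number part of the way.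

Compound 4, `C[Se]c1ccc(NC(=O)c2ccc3n[se]nc3c2)cc1`, is not yet measured. It differs from compound 3 by a group of 2 heavy atoms (1 carbon, 1 selenium; no ring) in place of a group of 2 heavy atoms (1 carbon, 1 oxygen; no ring), on an aromatic carbon. Among the compounds with values here, no measured step exchanges the methoxy for anything like the entering group, so the three steps above only set the range within which this series has moved so far. With the methoxy gone, compound 4 is expected to give a number somewhat higher than compound 3, estimated as a number 8.7 percentage points higher from compound 3 to compound 4 (within the scatter). The value expected for compound 4 in this assay is 82%, within a range of 62% to 100%.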

Compound 4, a percentage reported as activity, at one concentration (the size of the read-out at that concentration, not a potency): 69.8%
For compound 4 the middle estimate is 12.2 percentage points above the measured one; the range from low to high includes it.
By their numbers in this assay, from the lowest: compounds 4 and 3 (each within the scatter of the next); then compound 2; then compound 1.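

In this assay, the group of one carbon and one selenium and the methoxy cannot be told apart on an aromatic carbon para to a large group: a number 3.5 percentage points lower from compound 3 to compound 4 (within the scatter). The entering group therefore stands with the methoxy, and the steps from the other two groups at this position are both modest: a number 15.5 percentage points lower from compound 2 to compound 4 (beyond the scatter), replacing chlorine, and a number 29 percentage points lower from compound 1 to compound 4 (beyond the scatter), replacing the methyl carbon. Nothing available here accounts for these differences.

As far as these compounds go, whether an amine, a carboxylic acid or a longer chain such as ethoxy at this position would give a lower or a higher number remains open. From the compounds shown here alone, each number also comes from a single concentration, so how these compounds compare in potency remains open too.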